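From dimethylamino to azetidin-1-yl: expected clearance of compound 4

A few compounds are considered here, and "the series" means these few. Any claim that something is new, unique, unknown or untested is made for them only; others in the source may bear on it.

In an ADME assay on microsomes from liver (Rattus norvegicus, strain Sprague-Dawley) for metabolic stability, read by HPLC, using NADPH, with stated times of 5 min and 60 min, tested at 10 uM (a lower number here means slower removal, a higher number faster removal of the compound), compound 3 `CN(C)c1ccc(C(=O)NCc2ccc(NS(C)(=O)=O)cc2Cl)cc1` gives 25 mL.min-1.g-1. Compound 1 `CS(=O)(=O)Nc1ccc(CNC(=O)c2ccc(C34CC(C3)C4)cc2)c(Cl)c1` gives 17 mL.min-1.g-1, and the measured change is a 1.5-fold higher number from compound 1 to compound 3 (0.17 log units; within the scatter), so these two stand level. Compound 2 `CS(=O)(=O)Nc1ccc(CNC(=O)c2ccc(C(F)(F)F)cc2)c(Cl)c1` gives 9.6 mL.min-1.g-1, and here the measured change is a 2.6-fold higher number from compound 2 to compound 3 (0.42 log units; beyond the scatter).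

Compound 4 `CS(=O)(=O)Nc1ccc(CNC(=O)c2ccc(N3CCC3)cc2)c(Cl)c1` carries one change: azetidin-1-yl in place of dimethylamino on an aromatic carbon. In words, this is azetidin-1-yl in place of dimethylamino on an aromatic carbon, para to a large group. Among the compounds with values here, no measured pair compares these two groups directly, so the evidence is indirect. All three measured steps exchange the group at this one place. Two of them stay small. One is a 1.8-fold lower number from compound 1 to compound 2 (0.25 log units; within the scatter). The other is a 1.5-fold higher number from compound 1 to compound 3 (0.17 log units; within the scatter). Only the exchange of trifluoromethyl for dimethylamino goes beyond the scatter, and it is modest. Compound 1 also bears four-membered rings, though of carbon only, and its step of a 1.5-fold higher number from compound 1 to compound 3 (0.17 log units; within the scatter) gives no sign of a large shift. The exchange in compound 4 is expected to be no larger than these, so the expected result is a 1.1-fold lower number from compound 3 to compound 4 (0.06 log units; within the scatter), which is no step beyond the scatter. For compound 4 the estimated value in this assay is 22 mL.min-1.g-1, with an expected range from 12 mL.min-1.g-1 to 40 mL.min-1.g-1.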

Compound 4, intrinsic clearance in microsomes: 8.6 mL.min-1.g-1
Compound 4: middle estimate off by 2.6-fold (0.41 log units), on the high side; the whole stated range lies above it.
By their numbers in this assay, from the lowest: compounds 4, 2, 1 and 3 (each within the scatter of the next, the first and the last beyond it).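

In this assay, azetidin-1-yl in place of dimethylamino gives a 2.9-fold lower number from compound 3 to compound 4 (0.46 log units; beyond the scatter), so this place on the aromatic carbon, para to a large group, responds to an exchange between two small nitrogen-linked groups, and such a step is not safely read as neutral. Within the data shown here, the earlier compounds held only one step beyond the scatter, between dimethylamino and trifluoromethyl, which could have suggested that a nitrogen at this place goes with the higher number; compound 4 speaks against that reading, since it stands level with trifluoromethyl, at a 1.1-fold lower number from compound 2 to compound 4 (0.05 log units; within the scatter), and also with the bicyclic carbon group of compound 1, at a 2.0-fold lower number from compound 1 to compound 4 (0.30 log units; within the scatter). Nothing available here accounts for the gap between the two nitrogen-linked groups.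

The compounds shown leave open whether a larger ring on the same nitrogen, such as pyrrolidin-1-yl or morpholin-4-yl, would stand with compound 4 or with compound 3, and where a monomethylamino group would fall. They also leave open whether azetidin-1-yl in place of dimethylamino would give a step of similar size on a core without the chlorine.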